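This account rests on a few compounds, and the source may have more. Where it says the series, first, only, none or still open, it means among the compounds named here.

Working notes on the series.

For the measured compounds named here, compound 2 `C=CCc1cc(C(C)=O)c(O)cc1OCCCCCCC` stands highest of the two numbers measured so far in an assay on isolated protein for inhibition of leukotriene B4 receptor 1 (Homo sapiens), tested at 10 uM (on this read-out higher numbers stand for more inhibition at the one concentration tested (going by the name of the read-out) and lower numbers for less inhibition), where compound 2 gives 31%. Going by the values given here, the nearest number belongs to compound 1 `C=CCc1cc(C(C)=O)c(O)cc1OCC#N`, which in this assay gives 20%; the one step measured, hexyl in place of cyano on a saturated chain carbon bound to an oxygen on an aromatic ring, is a number 11 percentage points higher from compound 1 to compound 2 (beyond the scatter).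

Compound 3 `C=CCCCCOc1cc(O)c(C(C)=O)cc1CC=C`, not yet measured, differs from compound 2 by vinyl in place of propyl on a saturated chain carbon, four bonds along the chain from an oxygen on an aromatic ring. Among the compounds with values here, the only measured step concerns the same chain but alters it at the carbon bound to the ring oxygen, exchanging a nitrile for a hexyl, and its size is modest. Within the data shown here, the change to compound 3 is cut further out along the chain and trims the chain end from propyl to vinyl; no measured pair shows such an exchange, so the step it will bring in this assay has no direct precedent and is expected to stay within the scatter, in either direction.

Compound 3 is therefore estimated at 28%, between 14% and 42%. The expected step is a number 3 percentage points lower from compound 2 to compound 3 (within the scatter).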

Compound 3, a percentage reported as inhibition, at one concentration (the size of the read-out at that concentration, not a potency): 73%
Compound 3: the middle estimate sits 45 percentage points below what was measured, and the stated range ends below it.
By their numbers in this assay, from the lowest: compound 1; then compound 2; then compound 3.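

The far end of the chain on the ring oxygen turns out to be a sensitive place in this assay: vinyl in place of propyl, on a saturated chain carbon four bonds along the chain from an oxygen on an aromatic ring, gives a number 42 percentage points higher from compound 2 to compound 3 (beyond the scatter), a large step from a small exchange that leaves the chain otherwise unchanged. The step measured earlier, at the carbon bound to the ring oxygen, was only modest, whereas pent-4-en-1-yl in place of cyano at that same carbon gives a number 53 percentage points higher from compound 1 to compound 3 (beyond the scatter), so in these compounds the gain from replacing the nitrile depends on what stands at the chain end and not only on a hydrocarbon chain being present. Nothing available here accounts for the size of this step.

The compounds shown leave open whether the gain belongs to the double bond itself or would also come with an alkyne, a phenyl group or an amine at the chain end, and whether a longer chain ending in vinyl would hold the level of compound 3. As far as these compounds go, with inhibition read at one concentration only, how far the step reaches in terms of potency also stays open.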